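The compounds below may be only part of what the source reports. "The series", "measured", "known", "first", "only" and "open" are said of these compounds alone.

Measured so far in an ADME assay on Raji cells (Homo sapiens) for cytotoxicity, with a stated time of 72 h (on this read-out lower numbers stand for an effect already at smaller amounts and higher numbers for an effect only at larger amounts of compound), each entry a limit and not a number:
- compound 1 `O=C(Nc1ccc(-c2nc3ccccc3s2)cc1)c1cc([N+](=O)[O-])ccc1Cl` gives > 27000 nM as a limit
- compound 2 `O=C(Nc1ccc(Cl)c(-c2nc3ccccc3s2)c1)c1cc([N+](=O)[O-])ccc1Cl` gives > 25000 nM as a limit
- compound 3 `COc1ccc(NC(=O)c2cc([N+](=O)[O-])ccc2Cl)cc1-c1nc2ccccc2s1` gives > 25000 nM as a limit

Compound 2 has no exact place among these three, only its limit. The three entries fall on two limits (the limit of > 25000 nM in this assay, at which 2 of the 3 values shown sit; (the limit of > 27000 nM in this assay, at which 1 of the 3 values shown sits)).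

Compound 4 `O=C(Nc1ccc(Cl)cc1)c1cc([N+](=O)[O-])ccc1Cl` has not yet been measured. It is reached from compound 2 by a single change, hydrogen in place of 1,3-benzothiazol-2-yl on an aromatic carbon.

Among the measured compounds shown here, only one measured step involves a single change (a step that the two limits leave unreadable from compound 2 to compound 3). It has methoxy in place of chloro on an aromatic carbon, which is a different exchange, and it gives no size to carry over. With no readable size to build on, the step expected in this assay is none beyond the usual scatter, and no firm direction can be named. The expected step (a step that the limit leaves unreadable from compound 2 to compound 4) is therefore small. For compound 4 the estimate is 32000 nM as an expected value, with an expected range from 15000 nM up to 60000 nM for the measurement. A further limit is the most likely report for this compound, as it was for the three before it.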

Compound 4, half-maximal effective concentration: > 27000 nM
Compound 4 was reported as a limit; the forecaster's own chance of this, stated with the estimate: 85%; the middle value lies beyond the limit too.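

Compound 4, like compound 1 and compound 2, is reported only as a limit in this assay, and no size can be read for the step from either of them to compound 4. Whether hydrogen in place of 1,3-benzothiazol-2-yl changes the read-out at all stays open, as does the concentration at which any of these compounds reaches its half-maximal effect.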